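Compound 4 and the Benzyl Swap in Cytotoxicity

The compounds below may be only part of what the source reports. "The series", "measured", "known", "first", "only" and "open" are said of these compounds alone.

Compound 1 `COC(=O)c1c[nH]c2ccccc2c1=O`: > 20000 nM
Compound 2 `COC(=O)c1c[nH]c2ccc(OCc3ccccc3)cc2c1=O`: 7590 nM
Compound 3 `COC(=O)c1c[nH]c2cc(OCCCc3ccccc3)ccc2c1=O`: 1480 nM

These three compounds were tested in an ADME assay on J774 cells (Mus musculus) for cytotoxicity (on this read-out higher numbers stand for an effect only at larger amounts of compound and lower numbers for an effect already at smaller amounts), and only two of them returned true numbers. Compound 1 stands at a limit of the assay, > 20000 nM, and not at a number. Compound 2 holds the higher of the two true numbers, at 7590 nM in this series. Compound 3 gives 1480 nM as its number, and its gap to compound 2 lies beyond the usual scatter.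

Compound 4 `COC(=O)c1c[nH]c2ccc(Oc3ccc(F)cc3)cc2c1=O` has not yet been measured. It differs from compound 2 in one place: 4-fluorophenyl in place of benzyl on an oxygen on an aromatic ring. Among the compounds with values here, no pair of measured compounds differs in a single place, and the data therefore offer no direct precedent for this change.

In this assay the expected step, a 1.1-fold higher number from compound 2 to compound 4 (0.02 log units; within the scatter), is estimated to stay within the scatter. This expectation takes compound 2 at 7590 nM as its anchor, while the lower end of the range leans toward compound 3 at 1480 nM in allowing for a drop. For compound 4 the estimated value is 8000 nM, with an expected range from 3000 nM to 20000 nM.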

Compound 4, half-maximal effective concentration: > 20000 nM
Compound 4: a limit, no number; the forecaster's own chance of this, stated with the estimate: 25%; middle value at least 2.5-fold (0.39 log units) away from the limit.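

In this assay, within the data shown here, putting 4-fluorophenyl in place of benzyl on an oxygen on an aromatic ring gives an at least 2.6-fold higher number from compound 2 to compound 4 (0.42 log units; beyond the scatter), and this is the first change in a single place that the series can be read on. The two groups have the same count of heavy atoms and each carries one six-membered aromatic ring of carbon only, yet the step lies beyond the scatter, so this position responds to a change that leaves those counts in place. Its true size stays unknown, and the step marks only its lower end, as the reading is capped by the top of the assay's range: the limit of > 20000 nM in this assay, at which 2 of the 4 values shown sit.

The compounds shown do not separate the loss of the carbon link in benzyl from the arrival of the fluorine, and a plain phenyl on the same oxygen would tell these two apart. They also leave open how this position would respond to a group of another kind, such as an amine or a carboxylic acid at the end of a longer chain on that oxygen.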